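A methoxy for a methyl in compound 4

The source may hold more compounds than are shown below. What is called first, only, known or untested is meant among the compounds shown, and "the series" means these compounds.

In a functional assay on MGC-803 cells (Homo sapiens) for inhibition, read by CCK-8 assay, with a stated time of 48 h (on this read-out lower numbers stand for stronger inhibition and higher numbers for weaker inhibition), compound 1 `COc1ccc(CN(C(=O)CSC(=S)N2CCN(C)CC2)c2cc(OC)c(OC)c(OC)c2)cc1` gives 1280 nM and compound 2 `COc1ccc(CN(C(=O)CSC(=S)N2CCOCC2)c2cc(OC)c(OC)c(OC)c2)cc1` gives 2370 nM, with a 1.9-fold higher number from compound 1 to compound 2 (0.27 log units; within the scatter). Compound 3 `COc1ccc(CN(C(=O)CSC(=S)N2CCCc3cc(C)ccc32)c2cc(OC)c(OC)c(OC)c2)cc1`, at 6490 nM, carries the highest number of the three, with a 5.1-fold higher number from compound 1 to compound 3 (0.71 log units; beyond the scatter) and a 2.7-fold higher number from compound 2 to compound 3 (0.44 log units; beyond the scatter). Compound 4 `COc1ccc(CN(C(=O)CSC(=S)N2CCCc3cc(OC)ccc32)c2cc(OC)c(OC)c(OC)c2)cc1` has methoxy in place of methyl on an aromatic carbon. Each measured step exchanges the whole group on the thiocarbonyl carbon, and none tests this smaller change directly. Among the measured compounds shown here, with no such pair measured, no shift beyond the scatter is expected, and the expected step is a 1.2-fold lower number from compound 3 to compound 4 (0.07 log units; within the scatter). Compound 4 is estimated at 5500 nM, with an expected range of 2200 nM to 13000 nM.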

Compound 4, half-maximal inhibitory concentration: 8210 nM
Beside the measured number, compound 4's estimate is 1.5-fold (0.17 log units) below it, within the range that was stated.
By their numbers in this assay, from the lowest: compounds 1 and 2 (each within the scatter of the next); then compounds 3 and 4 (each within the scatter of the next).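

In this assay, among the compounds shown here, the first direct reading of this change, methoxy in place of methyl on an aromatic carbon of the fused system, stays within the scatter (a 1.3-fold higher number from compound 3 to compound 4 (0.10 log units; within the scatter)). The 6-methoxy-1,2,3,4-tetrahydroquinolin-1-yl group still stands beyond the scatter against morpholin-4-yl (a 3.5-fold higher number from compound 2 to compound 4 (0.54 log units; beyond the scatter)) and against 4-methylpiperazin-1-yl (a 6.4-fold higher number from compound 1 to compound 4 (0.81 log units; beyond the scatter)), as the 6-methyl group did. No measurement speaks to the reason for this result.

On these data alone, whether a hydroxyl, a fluorine or an amine on that same carbon would move the number remains open.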